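Swapping Sec-Butyl for Pyrazolyl on the Amide Nitrogen

The compounds below may be only part of what the source reports. "The series", "measured", "known", "first", "only" and "open" are said of these compounds alone.

In an assay on HEK293 cells for agonist activity at transient receptor potential cation channel subfamily M member 8 (Homo sapiens), read by fluorescence and calcium flux, with a stated time of 15 min (on this read-out higher numbers stand for an effect only at larger amounts of compound and lower numbers for an effect already at smaller amounts), compound 1 `CON(Cc1cccs1)C(=O)COc1ccc(C)cc1` gives 10 nM. Compound 2 `CCC(C)N(Cc1cccs1)C(=O)COc1ccc(C)cc1` gives 2000 nM in this assay, the higher of the two numbers measured, the jump being a 200-fold higher number from compound 1 to compound 2 (2.30 log units; beyond the scatter). Compound 3 `Cc1ccc(OCC(=O)N(Cc2cccs2)c2cn[nH]c2)cc1` differs from compound 2 by 1H-pyrazol-4-yl in place of sec-butyl on an amide-type nitrogen. For the measured compounds named here, the only measured step touching this position is a 200-fold higher number from compound 1 to compound 2 (2.30 log units; beyond the scatter), which shows the group on the amide-type nitrogen can shift the number strongly. Because compound 1, with a small oxygen-bearing group there, gives 10 nM, a lower number than compound 2 is expected, with wide uncertainty. Compound 3 is therefore expected to give 300 nM, within a range from 30 nM to 3000 nM, which would mean an expected step of a 6.7-fold lower number from compound 2 to compound 3 (0.82 log units; beyond the scatter).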

Compound 3, half-maximal effective concentration: 1.4 nM
For compound 3 the middle estimate is 210-fold (2.33 log units) above the measured one; the whole stated range lies above it.
By their numbers in this assay, from the lowest: compound 3; then compound 1; then compound 2.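

In this assay, the group on the amide-type nitrogen need not be a small one like methoxy to give a low number. Putting 1H-pyrazol-4-yl in place of sec-butyl gives a 1400-fold lower number from compound 2 to compound 3 (3.15 log units; beyond the scatter) and so recovers more than the whole loss seen with sec-butyl. The same ring in place of methoxy still gives a 7.1-fold lower number from compound 1 to compound 3 (0.85 log units; beyond the scatter) as a further, modest gain. No measurement available here explains why this ring does so well. The compounds shown leave open whether the ring nitrogens matter or any aromatic ring would serve, a question that phenyl in this place would address.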